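Methoxy Added to the Core of Compound 3

The source may report more compounds than this note shows. Statements on the series, on what has been measured and on what is new or still open speak of the compounds shown alone.

Three members of the series have been run in an ADME assay on MT2 cells (Homo sapiens) for cytotoxicity; on this read-out lower numbers stand for higher toxicity in this test and higher numbers for lower toxicity in this test. Compound 1 `COc1ccnc(Nc2ccc(Cl)c(OCC=C(C)C)c2)n1` gives 9000 nM, compound 2 `CC(C)=CCOc1cc(Nc2ncccn2)ccc1Cl` gives 2500 nM and compound 3 `C/C=C/COc1cc(Nc2ncccn2)ccc1Cl` gives 31000 nM. Compound 3 stands highest of the three numbers; compound 1 is the nearest to it and compound 2 the furthest, the latter gap being the large step of a 12-fold higher number from compound 2 to compound 3 (1.09 log units; beyond the scatter). Compound 4 `C/C=C/COc1cc(Nc2nccc(OC)n2)ccc1Cl` differs from compound 3 in one place: methoxy in place of hydrogen on an aromatic carbon. Within the data shown here, only one measured step bears on this change, a 3.6-fold lower number from compound 1 to compound 2 (0.56 log units; beyond the scatter), which is the same exchange run in the opposite direction and was modest but beyond the scatter. Read in reverse, a modest rise in number is expected from compound 3 to compound 4, a 3.5-fold higher number from compound 3 to compound 4 (0.55 log units; beyond the scatter). Compound 4 is therefore estimated at 110000 nM in this assay, with an expected range from 40000 nM to 300000 nM, and the measurement may return only an upper limit of the assay.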

Compound 4, half-maximal cytotoxic concentration: 17000 nM
For compound 4 the middle estimate is 6.5-fold (0.81 log units) above the measured one; the measured number lies below the stated range.
By their numbers in this assay, from the lowest: compound 2; then compounds 1, 4 and 3 (each within the scatter of the next, the first and the last beyond it).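

In this assay, methoxy in place of hydrogen on this aromatic carbon, next to the ring nitrogen, gives a 1.8-fold lower number from compound 3 to compound 4 (0.26 log units; within the scatter). The methoxy exchange therefore depends on the chain present elsewhere in the molecule, and the step seen with the 2-methylprop-1-en-1-yl chain does not carry over to the prop-1-en-1-yl chain: the same change on two cores in this assay, a 3.6-fold lower number (0.56 log units; beyond the scatter) from compound 1 to compound 2 and a 1.8-fold higher number (0.26 log units; within the scatter) from compound 4 to compound 3, 6.6-fold (0.82 log units) apart, beyond the scatter of two such steps

Read from the chain, the same exchange of 2-methylprop-1-en-1-yl for prop-1-en-1-yl gives only a 1.9-fold higher number from compound 1 to compound 4 (0.28 log units; within the scatter) where methoxy is present, so the chain step also depends on this position: the same change on two cores in this assay, a 12-fold higher number (1.09 log units; beyond the scatter) from compound 2 to compound 3 and a 1.9-fold higher number (0.28 log units; within the scatter) from compound 1 to compound 4, 6.6-fold (0.82 log units) apart, beyond the scatter of two such steps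

These four compounds cover only two chains and two groups at this position, so it remains open whether the dependence extends to other pairs. As far as these compounds go, how an amine at this aromatic carbon, or a longer chain on the oxygen, would read in this assay also remains open.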